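This account rests on a few compounds, and the source may have more. Where it says the series, first, only, none or still open, it means among the compounds named here.

Among the compounds with values here, compound 2 `CN(C)CCn1cnnc1-c1cc(Oc2ccc(NC(=O)N/N=C/c3cccc(Cl)c3Cl)cc2F)ccn1` is the stronger of the two compounds measured so far: in a functional assay on HT-29 cells (Homo sapiens) for cytotoxicity, read by MTT assay, with a stated time of 72 h (a lower number here means a stronger inhibitor, a higher number a weaker inhibitor), compound 2 gives 130 nM, while compound 1 `COc1ccc(OC)c(/C=N/NC(=O)Nc2ccc(Oc3ccnc(-c4nncn4CCN(C)C)c3)c(F)c2)c1` gives 2070 nM. Within the data shown here, the one step measured, a 16-fold lower number from compound 1 to compound 2 (1.20 log units; beyond the scatter), came from swapping the ring on the carbon with a double bond to nitrogen, so that position clearly matters. Compound 3 `CN(C)CCn1cnnc1-c1cc(Oc2ccc(NC(=O)N/N=C/c3cc(Br)c(O)c(Br)c3)cc2F)ccn1` changes the same ring again: 3,5-dibromo-4-hydroxyphenyl in place of 2,3-dichlorophenyl on a carbon with a double bond to nitrogen. Among the measured compounds shown here, no measured step bears directly on this particular swap; the only guide is that the dichlorophenyl ring of compound 2 was much better than the dimethoxyphenyl ring of compound 1, and moving away from it toward a ring with a hydroxyl group may give some of that back. Compound 3 is therefore expected to be somewhat weaker in this assay, with a step of a 3.1-fold higher number from compound 2 to compound 3 (0.49 log units; beyond the scatter), estimated at 400 nM within a range of 100 nM to 1600 nM.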

Compound 3, half-maximal inhibitory concentration: 2670 nM
Compound 3: the middle estimate sits 6.7-fold (0.82 log units) below what was measured; the measured number lies above the stated range.
By their numbers in this assay, from the lowest: compound 2; then compounds 1 and 3 (each within the scatter of the next).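

In this assay the gain seen with the 2,3-dichlorophenyl ring does not extend to every ring carrying two halogens, since the 3,5-dibromo-4-hydroxyphenyl ring gives a 21-fold higher number from compound 2 to compound 3 (1.31 log units; beyond the scatter) and so a large loss. The step of a 1.3-fold higher number from compound 1 to compound 3 (0.11 log units; within the scatter) means that this ring and the 2,5-dimethoxyphenyl ring cannot be told apart, so among these three rings on the carbon with a double bond to nitrogen, only the 2,3-dichlorophenyl ring stands out. No measurement here explains why the rings differ in this way.

The compounds shown cannot separate the part played by the hydroxyl group from that of the two bromine atoms, as both change together with the ring pattern. A ring with bromine alone, or with an amine in place of the hydroxyl group, would address that question more directly.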